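Aryl hydrazone variation on the shared core, cytotoxicity

The compounds below may be only part of what the source reports. "The series", "measured", "known", "first", "only" and "open" are said of these compounds alone.

In an ADME assay on THP-1 cells (Homo sapiens) for cytotoxicity (on this read-out lower numbers stand for stronger inhibition and higher numbers for weaker inhibition), compound 1 `COc1ccccc1-c1nnc(-c2ccc(C(=O)N/N=C/c3cc(O)ccc3O)cc2)o1` gives 100000 nM and compound 2 `COc1ccccc1-c1nnc(-c2ccc(C(=O)N/N=C/c3ccccc3[N+](=O)[O-])cc2)o1` gives 161000 nM; of the two numbers, that of compound 2 lies within the scatter of compound 1, as shown by a 1.6-fold higher number from compound 1 to compound 2 (0.21 log units; within the scatter). Compound 3 `COc1ccccc1-c1nnc(-c2ccc(C(=O)N/N=C/c3cccnc3)cc2)o1` carries pyridin-3-yl in place of 2-nitrophenyl on a carbon with a double bond to nitrogen. Within the data shown here, the one measured step, a 1.6-fold higher number from compound 1 to compound 2 (0.21 log units; within the scatter), also exchanged the aryl group on that carbon and stayed within the scatter, so no step beyond the scatter is expected in this assay, estimated as a 1.1-fold lower number from compound 2 to compound 3 (0.03 log units; within the scatter). Compound 3 is therefore expected near 150000 nM, estimated between 50000 nM and 400000 nM.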

Compound 3, half-maximal inhibitory concentration: 167000 nM
The estimate for compound 3 lay 1.1-fold (0.05 log units) below the measured number; the measured number falls inside the stated range.
By their numbers in this assay, from the lowest: compounds 1, 2 and 3 (each within the scatter of the next).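

In this assay, pyridin-3-yl on a carbon with a double bond to nitrogen reads level with both earlier aryl groups (a 1.0-fold higher number from compound 2 to compound 3 (0.02 log units; within the scatter); a 1.7-fold higher number from compound 1 to compound 3 (0.22 log units; within the scatter)). An aromatic ring with a hetero atom therefore joins the two carbon-only rings at this position, with all three compounds within the scatter of one another. No measured evidence bears on this flat result.

Still open, on these data alone, is whether any group here gives a step beyond the scatter. A carboxylic acid or an amine on the aryl ring, or a saturated alkyl chain in its place, would test this.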